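The compounds below may be only part of what the source reports. "The series", "measured", "known", "first", "only" and "open" are said of these compounds alone.

Measured in a functional assay on MCF7 cells (Homo sapiens) for inhibition, read by sulforhodamine B assay, with a stated time of 48 h; on this read-out lower numbers stand for stronger inhibition of growth and higher numbers for weaker inhibition of growth:
Compound 1 `CC1=CC[C@H](C(C)(C)NC(=S)N/N=C/c2ccccc2)CC1` gives 84400 nM.
Compound 2 `CC1=CC[C@H](C(C)(C)NC(=S)N/N=C/c2ccc(O)cc2)CC1` gives the limit of this assay, > 100000 nM.
Compound 3 `CC1=CC[C@H](C(C)(C)NC(=S)N/N=C/c2ccc(F)cc2)CC1` gives the limit of this assay, > 100000 nM.

Compound 3 thus stands not on a number but on a limit, and the limit of > 100000 nM in this assay, at which 2 of the 3 values shown sit, marks where two of the three values sit; only compound 1 is read as a number. Compound 4 `CC1=CC[C@H](C(C)(C)NC(=S)N/N=C/c2ccccc2Cl)CC1` differs from compound 3 by 2-chlorophenyl in place of 4-fluorophenyl on a carbon with a double bond to nitrogen. Of the measured steps, an at least 1.1-fold higher number from compound 1 to compound 3 (0.07 log units; that floor lies within the scatter) shows that fluoro in place of hydrogen moves the value from a number to the limit, while a step that the two limits leave unreadable from compound 2 to compound 3 cannot be read at all. Going by the values given here, no measured step puts a chloro on the ring or shifts a substituent, so the change to compound 4 rests on no comparable pair. The step of a number no higher from compound 3 to compound 4 (the limit leaves the size open) is therefore expected to show nothing readable beyond the scatter in this assay. Compound 4 is estimated at 100000 nM, between 50000 nM and 250000 nM, and is expected most likely to return the limit again.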

Compound 4, concentration for total growth inhibition: 98300 nM
Compound 4: the middle estimate sits 1.0-fold (0.01 log units) above what was measured, and the stated range covers the measured number.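

In this assay, compound 4 gives a number rather than a limit, so a 2-chlorophenyl group on this carbon with a double bond to nitrogen yields a readable value. Going by these compounds alone, putting a chloro on the ring gives a 1.2-fold higher number from compound 1 to compound 4 (0.07 log units; within the scatter), the first measured step of this kind, and it does not move the value beyond the scatter. The other two steps, an at least 1.0-fold lower number from compound 3 to compound 4 (0.00 log units; that floor lies within the scatter) and an at least 1.0-fold lower number from compound 2 to compound 4 (0.00 log units; that floor lies within the scatter), are floors within the scatter, so the new number does not set compound 4 apart from either limit compound: the limit of > 100000 nM in this assay, at which 2 of the 4 values shown sit.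

The compounds shown leave open whether an amine or a carboxylic acid on the aromatic ring would give a value clearly apart from these. They also leave open whether a longer chain in place of the aromatic ring would do so.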